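Solubility notes on a sparingly soluble series

The source may report more compounds than this note shows. Statements on the series, on what has been measured and on what is new or still open speak of the compounds shown alone.

Measured so far:
compound 1 `CC1(C)C(=O)N(c2ccc(SC(F)(F)F)cc2)C(=O)N1Cc1ccncc1`: < 0.02 ug/mL
compound 2 `CN1CCN(c2cc(CN3C(=O)N(c4ccc(SC(F)(F)F)cc4)C(=O)C3(C)C)ccn2)CC1`: 0.159 ug/mL
compound 3 `CC1(C)C(=O)N(c2ccc(SC(F)(F)F)cc2)C(=O)N1Cc1ccnc(F)c1`: 0.032 ug/mL

In a physicochemical assay for solubility, read by nephelometry (a lower number here means a less soluble compound, a higher number a more soluble compound), compound 1 gives no number, only a limit, (the limit of < 0.02 ug/mL in this assay, at which 1 of the 3 values shown sits). Two measured steps start from it: an at least 7.9-fold higher number from compound 1 to compound 2 (0.90 log units; beyond the scatter), and an at least 1.6-fold higher number from compound 1 to compound 3 (0.20 log units; that floor lies within the scatter). Between the two substituted analogues, a 5.0-fold lower number from compound 2 to compound 3 (0.70 log units; beyond the scatter).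

Compound 4 `CC1(C)C(=O)N(c2ccc(SC(F)(F)F)cc2)C(=O)N1Cc1ccnc(NCc2ccccc2)c1` carries benzylamino in place of hydrogen on an aromatic carbon. For the measured compounds named here, the entering group is neither a 4-methylpiperazin-1-yl nor a fluoro, so no measured step copies this change; the step toward compound 3 is the closer reference in size. The step of an at least 1.5-fold higher number from compound 1 to compound 4 (0.17 log units; that floor lies within the scatter) is therefore expected to stay small, with the limit still a real possibility. Compound 4 is estimated at 0.03 ug/mL, within 0.01 ug/mL to 0.1 ug/mL.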

Compound 4, solubility: < 0.026 ug/mL
Compound 4 was reported as a limit; the forecaster's own chance of this, stated with the estimate: 40%; middle value at least 1.1-fold (0.06 log units) away from the limit.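

Compound 4 gives only a limit in this assay, and its step from compound 1, itself a limit, cannot be read: the limit of < 0.026 ug/mL in this assay, at which 1 of the 4 values shown sits.

A large group on this aromatic carbon next to the ring nitrogen therefore does not by itself reproduce the result of compound 2: benzylamino in place of 4-methylpiperazin-1-yl gives an at least 6.1-fold lower number from compound 2 to compound 4 (0.78 log units; beyond the scatter). Benzylamino in place of fluoro gives an at least 1.2-fold lower number from compound 3 to compound 4 (0.09 log units; that floor lies within the scatter), which leaves compound 3 and compound 4 unseparated.

Still open, from the compounds shown here alone, is whether the gain in compound 2 extends to other cyclic amines, such as morpholine or unsubstituted piperazine, at this position. A simple dimethylamino group would also help separate the ring amine from the benzylamino result.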